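The compounds below may be only part of what the source reports. "The series", "measured", "known", "first", "only" and "open" are said of these compounds alone.

Measured compounds: compound 1 `Cc1nn(C)c2c1C(c1ccccc1)=NCC(=O)N2` gives 10 mg/kg; compound 2 `CCc1nn(C)c2c1C(c1ccccc1)=NCC(=O)N2` gives 2.5 mg/kg; compound 3 `CCCc1nn(C)c2c1C(c1ccccc1Cl)=NCC(=O)N2` gives > 40 mg/kg.

All three were tested in a functional assay on the whole organism (strain Holtzman) with Rattus norvegicus as the target; on this read-out higher numbers stand for an effect only at larger amounts of compound and lower numbers for an effect already at smaller amounts. From compound 1 to compound 2 the change is methyl in place of hydrogen on a saturated chain carbon bound to an aromatic carbon, and it gave a 4.0-fold lower number from compound 1 to compound 2 (0.60 log units; beyond the scatter). For compound 3 the read-out is only a limit of the assay, (the limit of > 40 mg/kg in this assay, at which 1 of the 3 values shown sits), not a number. How the core of compound 3 differs from that of compound 1 is not broken down here.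

Compound 4 `CCCCc1nn(C)c2c1C(c1ccccc1Cl)=NCC(=O)N2` is not yet measured. It differs from compound 3 by methyl in place of hydrogen on a saturated chain carbon, three bonds along the chain from an aromatic carbon. This is the same kind of change as that from compound 1 to compound 2, but the place is not the same: there the methyl entered on a saturated chain carbon bound to an aromatic carbon, here on a saturated chain carbon three bonds along the chain from an aromatic carbon. Among the compounds with values here, the earlier step is the only guide, and compound 3 itself sits at a limit, so the expectation for compound 4 is weak. Compound 4 is estimated at 40 mg/kg, between 12 mg/kg and 120 mg/kg, an expected step of a number no higher from compound 3 to compound 4 (the limit leaves the size open), and a further limit is thought likely.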

Compound 4, minimum effective dose: > 40 mg/kg
Compound 4 gave a limit, no number; the forecaster's own chance of this, stated with the estimate: 65%; the middle value sits exactly at the limit.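

Compound 3 and compound 4 each give only a limit, not a number, so no step between them can be read: the limit of > 40 mg/kg in this assay, at which 2 of the 4 values shown sit.

The compounds shown leave open whether propyl to butyl changes the effective dose at all, and whether the gain seen from compound 1 to compound 2 carries over to the core of compound 3.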